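Carbamoyl in place of aminomethyl on the core

This account rests on a few compounds, and the source may have more. Where it says the series, first, only, none or still open, it means among the compounds named here.

Among the measured compounds shown here, compound 1 `CCN(CC)C/C1=C/C[C@](C)(CCC=C(C)C)/C=C/[C@@H](OC(=O)C=C(C)C)[C@](C)(O)/C=C/C1=O` is the only member of this series with a number so far: in a functional assay on HL-60 cells (Homo sapiens) for antiproliferative activity, read by MTT assay, with a stated time of 48 h (on this read-out higher numbers stand for weaker inhibition and lower numbers for stronger inhibition), compound 1 gives 140 nM. Compound 2 `CC(C)=CCC[C@]1(C)/C=C/[C@@H](OC(=O)C=C(C)C)[C@](C)(O)CCC(=O)/C(CO)=C\C1` gives only a limit, > 40000 nM, in this assay; (the limit of > 40000 nM in this assay, at which 1 of the 2 values shown sits). Compound 3 `CC(C)=CCC[C@]1(C)/C=C/[C@@H](OC(=O)C=C(C)C)[C@](C)(O)/C=C/C(=O)/C(C(=O)N(C(C)C)C(C)C)=C\C1` is not yet measured. It differs from compound 1 by diisopropylcarbamoyl in place of (diethylamino)methyl on a double-bonded ring carbon. For the measured compounds named here, no step between two measured compounds has been recorded, so no measured step can guide the size of the change here. A loss of potency beyond the scatter is expected, with the step of a 4.3-fold higher number from compound 1 to compound 3 (0.63 log units; beyond the scatter). Compound 3 is thus estimated at 600 nM in this assay, likely between 120 nM and 3000 nM.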

Compound 3, half-maximal inhibitory concentration: 12700 nM
For compound 3 the middle estimate is 21-fold (1.33 log units) below the measured one, and the stated range ends below it.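

On the double-bonded ring carbon, the group carried matters strongly: diisopropylcarbamoyl in place of (diethylamino)methyl gives, in this assay, a 91-fold higher number from compound 1 to compound 3 (1.96 log units; beyond the scatter). Among the compounds shown here, this is the first measured step, and it marks this position as sensitive to the exchange, though compound 3 still gives a measured number, 12700 nM. Nothing shown accounts for the size of the step.

Still open, going by these compounds, is whether the loss follows the carbonyl or the isopropyl groups. A diethylcarbamoyl or (diisopropylamino)methyl group on this carbon would separate the two.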